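The source may hold more compounds than are shown below. What is called first, only, known or untested is meant among the compounds shown, and "the series" means these compounds.

In a functional assay on HL-60 cells (Homo sapiens) for antiproliferative activity, read by MTT assay, with a stated time of 72 h (on this read-out higher numbers stand for weaker inhibition and lower numbers for stronger inhibition), compound 1 (`COc1cc(-c2ncnn2-c2cccc(N)c2)cc(OC)c1OC`), with 3-aminophenyl, gives > 10000 nM, which is a limit of the assay. Compound 2 (`COc1cc(-c2ncnn2-c2ccc(N)cc2)cc(OC)c1OC`), with 4-aminophenyl, gives > 10000 nM, also only a limit. For the measured compounds named here, the sole measured step, a step that the two limits leave unreadable from compound 1 to compound 2, has no readable size to carry forward. Compound 3 (`COc1ccc(-n2ncnc2-c2cc(OC)c(OC)c(OC)c2)cc1`) differs from compound 2 by methoxy in place of amino on an aromatic carbon, para to a large group. Stronger inhibition in this assay is tentatively expected, though another limit remains possible. The expected move is an at least 3.3-fold lower number from compound 2 to compound 3 (0.52 log units; beyond the scatter). The estimate for compound 3 is 3000 nM, within an expected range of 150 nM to 20000 nM.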

Compound 3, half-maximal inhibitory concentration: 6200 nM
Beside the measured number, compound 3's estimate is 2.1-fold (0.32 log units) below it; the measured number falls inside the stated range.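

For the compounds shown here, with 4-methoxyphenyl on the aromatic nitrogen, compound 3 gives the first value in this assay that is a number and not a limit. Methoxy in place of amino at this position, para to a large group, gives an at least 1.6-fold lower number from compound 2 to compound 3 (0.20 log units; that floor lies within the scatter), and the change of 3-aminophenyl to 4-methoxyphenyl gives an at least 1.6-fold lower number from compound 1 to compound 3 (0.20 log units; that floor lies within the scatter), so both steps have only a floor and no fixed size. The other two compounds give no number to measure against: the limit of > 10000 nM in this assay, at which 2 of the 3 values shown sit.

As far as these compounds go, whether ethoxy or hydroxy at the same place would lower the number further remains open. So does the effect of 3-methoxyphenyl on the aromatic nitrogen.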